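This account rests on a few compounds, and the source may have more. Where it says the series, first, only, none or still open, it means among the compounds named here.

Measured so far:
- compound 1 `Cc1cccc(Oc2nc(Nc3ccc(C#N)cc3)nc3ccccc23)c1`: 355000 nM
- compound 2 `N#Cc1ccc(Nc2nc(Oc3ccc(Cl)cc3)c3ccccc3n2)cc1`: 198000 nM

The two compounds share one core and differ only in the aryl group carried on the ether oxygen. In an ADME assay on MT4 cells (Homo sapiens) for cytotoxicity, read by MTT assay, with a stated time of 4 days (on this read-out lower numbers stand for higher toxicity in this test and higher numbers for lower toxicity in this test), compound 1 gives 355000 nM, and compound 2 gives 198000 nM. Within the data shown here, the one step between them, a 1.8-fold lower number from compound 1 to compound 2 (0.25 log units; within the scatter), does not leave the scatter, so compound 2 stands alongside compound 1 rather than apart from it, and neither can be called the more or less toxic of the two.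

Compound 3 `Cc1ccc(Oc2nc(Nc3ccc(C#N)cc3)nc3ccccc23)cc1` is not yet measured. Against compound 2 it shows the change (methyl in place of chloro on an aromatic carbon), that is, 4-chlorophenoxy to 4-methylphenoxy. Among the measured compounds shown here, the only step that bears on it is the exchange of the aryl group from compound 1 to compound 2, a 1.8-fold lower number from compound 1 to compound 2 (0.25 log units; within the scatter), which swapped a methyl-bearing ring for a chloro-bearing one and stayed within the scatter. On that basis the step expected in this assay from compound 2 to compound 3 is small or none, a 1.3-fold higher number from compound 2 to compound 3 (0.12 log units; within the scatter). Compound 3 is therefore estimated at 260000 nM, within 120000 nM to 550000 nM.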

Compound 3, half-maximal cytotoxic concentration: 87000 nM
For compound 3 the middle estimate is 3.0-fold (0.48 log units) above the measured one; the whole stated range lies above it.
By their numbers in this assay, from the lowest: compound 3; then compounds 2 and 1 (each within the scatter of the next).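

In this assay, the aryl group on the ether oxygen proves able to move the number beyond the scatter, which the earlier pair did not show: methyl in place of chloro on an aromatic carbon, para to a large group, gives a 2.3-fold lower number from compound 2 to compound 3 (0.36 log units; beyond the scatter). Where the methyl sits also counts, since 4-methylphenyl in place of 3-methylphenyl gives a 4.1-fold lower number from compound 1 to compound 3 (0.61 log units; beyond the scatter), which makes compound 3 the most toxic of the three in this test, although both steps are modest. Nothing measured here bears on why these two changes lower the number.

The three compounds leave open whether this drop belongs to the methyl group itself or would also appear with another group in its place, such as a methoxy, an ethyl or an amine on the same carbon. They also leave open whether chloro responds to its place on the ring as methyl does, a question that 3-chlorophenyl on the same oxygen would address.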